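The source may hold more compounds than are shown below. What is called first, only, known or untested is meant among the compounds shown, and "the series" means these compounds.

Compound 1 `CC(O)(CSc1ccc(C(F)(F)F)cc1)C(=O)Nc1ccc(S(F)(F)(F)(F)F)cc1` and compound 2 `CC(O)(CSc1cccc(C(F)(F)F)c1)C(=O)Nc1ccc(S(F)(F)(F)(F)F)cc1` share a core that carries a trifluoromethyl-substituted phenyl ring on a sulfur. In a functional assay on CWR22R cells (Homo sapiens) for antiproliferative activity, read by propidium iodide staining, with a stated time of 96 h (on this read-out lower numbers stand for stronger inhibition and higher numbers for weaker inhibition), compound 1 gives 14800 nM and compound 2 gives 23400 nM, so the change 3-(trifluoromethyl)phenyl in place of 4-(trifluoromethyl)phenyl on a sulfur made a step of a 1.6-fold higher number from compound 1 to compound 2 (0.20 log units; within the scatter). In this assay compound 3 `CC(O)(CS(=O)(=O)c1ccc(C(F)(F)F)cc1)C(=O)Nc1ccc(S(F)(F)(F)(F)F)cc1` gives 28900 nM; how its core differs from that of compound 1 is not broken down here. Compound 4 `CC(O)(CS(=O)(=O)c1cccc(C(F)(F)F)c1)C(=O)Nc1ccc(S(F)(F)(F)(F)F)cc1` is not yet measured. It differs from compound 3 by 3-(trifluoromethyl)phenyl in place of 4-(trifluoromethyl)phenyl on a sulfonyl sulfur, the same kind of change as that between compound 1 and compound 2, though the place is a sulfonyl sulfur rather than a sulfur, each with a saturated chain carbon as other neighbour. Because the earlier step was a 1.6-fold higher number from compound 1 to compound 2 (0.20 log units; within the scatter), compound 4 is expected to give about 40000 nM, a step of a 1.4-fold higher number from compound 3 to compound 4 (0.14 log units; within the scatter), most likely between 18000 nM and 90000 nM.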

Compound 4, half-maximal inhibitory concentration: 23800 nM
Compound 4: middle estimate off by 1.7-fold (0.23 log units), on the high side, within the range that was stated.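

In this assay, 3-(trifluoromethyl)phenyl in place of 4-(trifluoromethyl)phenyl on a sulfonyl sulfur gives a 1.2-fold lower number from compound 3 to compound 4 (0.08 log units; within the scatter). Set beside the same change on a sulfur, the two steps do not differ by more than repeated measurements would: the same change on two cores in this assay, a 1.6-fold higher number (0.20 log units; within the scatter) from compound 1 to compound 2 and a 1.2-fold lower number (0.08 log units; within the scatter) from compound 3 to compound 4, 1.9-fold (0.28 log units) apart, within the scatter of two such steps. On these two cores, then, the change made no step beyond the scatter, but the data fix no direction for it and cannot speak for other cores in the series.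

As far as these compounds go, it remains open whether a nitrile or a chlorine in place of trifluoromethyl on this phenyl ring would give a step beyond the scatter. From the compounds shown here alone, it is also open how the same change behaves on a core with an oxygen or an amine in place of the sulfur.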